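Replacing 1H-indol-3-yl with 4-iodophenyl on the shared core

The compounds below may be only part of what the source reports. "The series", "measured", "known", "first", "only" and "open" are said of these compounds alone.

Measured in a functional assay on DU-145 cells (Homo sapiens) for inhibition, read by trypan blue exclusion, with a stated time of 96 h; a higher number here means a weaker inhibitor of growth, a lower number a stronger inhibitor of growth:
- compound 1 `COc1ccc(/C=C(/Sc2ccc(Br)cc2)C(=O)c2ccc(Br)cc2)cc1`: 25000 nM
- compound 2 `O=C(/C(=C\c1ccc(Br)cc1)Sc1ccc(Br)cc1)c1ccc(Br)cc1`: 1000 nM
- compound 3 `O=C(/C(=C\c1c[nH]c2ccccc12)Sc1ccc(Br)cc1)c1ccc(Br)cc1`: 1000 nM

Compound 3 stands level with compound 2, and together they hold the lowest number of the three. The comparison shows no change at the digits printed from compound 2 to compound 3 (within the scatter). The next structure, compound 4 `O=C(/C(=C\c1ccc(I)cc1)Sc1ccc(Br)cc1)c1ccc(Br)cc1`, arises through (4-iodophenyl in place of 1H-indol-3-yl on a double-bonded chain carbon bound to a double-bonded chain carbon), with 4-iodophenyl in place of 1H-indol-3-yl on a double-bonded chain carbon bound to a double-bonded chain carbon.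

Among the compounds with values here, three measured steps bear on this change. At this same place, the exchange of 4-bromophenyl for 1H-indol-3-yl gave the result above, while moving away from 4-methoxyphenyl gave a 25-fold lower number from compound 1 to compound 3 (1.40 log units; beyond the scatter). Bromo in place of methoxy on an aromatic carbon gave a 25-fold lower number from compound 1 to compound 2 (1.40 log units; beyond the scatter). Within the data shown here, the entering 4-iodophenyl resembles the 4-bromophenyl of compound 2 in name, but no measured compound carries iodo, so this comparison remains uncertain.

The step expected is no change at the digits printed from compound 3 to compound 4 (within the scatter), so no move beyond the scatter is anticipated. For compound 4 the estimated value in this assay is 1000 nM, with an expected range of 350 nM to 3000 nM.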

Compound 4, concentration for 50% growth inhibition: 1000 nM
Compound 4: the middle estimate sits on the measured number at the digits printed, and the stated range covers the measured number.
By their numbers in this assay, from the lowest: compounds 2, 3 and 4 (each within the scatter of the next); then compound 1.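

In this assay, 4-iodophenyl in place of 1H-indol-3-yl on a double-bonded chain carbon bound to a double-bonded chain carbon gave no change at the digits printed from compound 3 to compound 4 (within the scatter), and iodo in place of bromo on an aromatic carbon gave no change at the digits printed from compound 2 to compound 4 (within the scatter). Starting instead from the methoxy group, the change to iodo gave a 25-fold lower number from compound 1 to compound 4 (1.40 log units; beyond the scatter), so the large step first seen with bromo also appears with iodo. At this place, 4-bromophenyl, 1H-indol-3-yl and 4-iodophenyl now read within the scatter of one another, and only the 4-methoxyphenyl of compound 1 stands apart.

Nothing shown here accounts for why these three groups read alike. From the compounds shown here alone, it remains open how a 4-aminophenyl or 4-carboxyphenyl group at this place would compare with them.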